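Notes on the change from compound 3 to compound 4

The compounds below may be only part of what the source reports. "The series", "measured", "known", "first", "only" and "open" are said of these compounds alone.

The series shares one core carrying a nitrile and a pyrrolidinyl group; the compounds differ in the group attached on the double-bonded ring carbon. Compound 1 `N#CC1=C(NCC(=O)N2CCOCC2)N(c2ccccc2)C(=O)N2CCCCC(N3CCCC3)C12` gives 43.9% in a functional assay on the whole organism (strain albino) for inhibition, with Rattus norvegicus as the target, read by paw edema, with a stated time of 1 h, at a dose of 20 mmol/kg by the intraperitoneal route; on this read-out lower numbers stand for less inhibition and higher numbers for more inhibition at the one dose given (going by the name of the read-out). Compound 2 `COc1ccc(N/C=N/C2=C(C#N)C3C(N4CCCC4)CCCCN3C(=O)N2c2ccccc2)cc1` gives 20.6%. Compound 3 `CCOC(=O)C(=O)NC1=C(C#N)C2C(N3CCCC3)CCCCN2C(=O)N1c1ccccc1` gives 71.2%, the highest of the three, with a number 27.3 percentage points higher from compound 1 to compound 3 (beyond the scatter) and a number 50.6 percentage points higher from compound 2 to compound 3 (beyond the scatter) both beyond the scatter.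

Compound 4 `N#CC1=C(NC(=O)c2ccccc2O)N(c2ccccc2)C(=O)N2CCCCC(N3CCCC3)C12` is not yet measured. Against compound 3 the change is 2-hydroxyphenyl in place of ethoxycarbonyl on a carbonyl carbon.

Within the data shown here, no measured step replaces an ethoxycarbonyl with an aryl group on a carbonyl carbon, so the expectation rests on analogy. The two steps that bear on it are those into compound 3: a number 27.3 percentage points higher from compound 1 to compound 3 (beyond the scatter) and a number 50.6 percentage points higher from compound 2 to compound 3 (beyond the scatter), both modest to large and both pointing to the (ethoxycarbonyl)carbonyl group as the best of the groups seen so far. Among the measured compounds shown here, the one measured compound bearing a six-membered aromatic ring on this position, compound 2, stands lowest. A loss on leaving compound 3 is therefore expected, of moderate size: the estimated step is a number 23.2 percentage points lower from compound 3 to compound 4 (beyond the scatter). Compound 4 is estimated at 48%, in a range from 25% to 70%.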

Compound 4, a percentage reported as inhibition, in the whole organism at one dose (the size of the read-out at that dose, not a potency): 44.7%
The estimate for compound 4 lay 3.3 percentage points above the measured number; the range from low to high includes it.
By their numbers in this assay, from the lowest: compound 2; then compounds 1 and 4 (each within the scatter of the next); then compound 3.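

In this assay, the exchange of ethoxycarbonyl for 2-hydroxyphenyl on the carbonyl carbon gives a number 26.5 percentage points lower from compound 3 to compound 4 (beyond the scatter) as the first step made directly at this place, so the carbonyl on the amine nitrogen does not by itself hold the number of compound 3, and the group on that carbonyl counts. A six-membered aromatic ring in the substituent does not by itself go with the low number of compound 2 either, as a number 24.1 percentage points higher from compound 2 to compound 4 (beyond the scatter) shows for two substituents that both carry such a ring. Two quite different substituents, (2-hydroxyphenyl)carbonyl and ((morpholin-4-yl)carbonyl)methyl, also read alike here, with a number 0.8 percentage points higher from compound 1 to compound 4 (within the scatter) on the amine nitrogen, so the shape of the read-out across this position is not a simple matter of having an aromatic ring or lacking one.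

No independent evidence bears on any of these steps. Still open, as far as these compounds go, is whether the hydroxy group of the 2-hydroxyphenyl plays any part in the reading, and how an unsubstituted phenyl, a carboxylic acid or a longer alkyl ester on the same carbonyl carbon would read.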